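This account rests on a few compounds, and the source may have more. Where it says the series, first, only, none or still open, it means among the compounds named here.

Notes on the amide series, read in a functional assay on A549 cells (Homo sapiens) for cytotoxicity, read by MTT assay (a higher number here means a weaker inhibitor, a lower number a stronger inhibitor), throughout. Compound 1 (`CCn1cc(C(=O)Nc2ccccc2)c(=O)c2cc(F)c(N3CCNC(C)C3)c(F)c21`) gives 39300 nM and compound 2 (`CCn1cc(C(=O)Nc2ccccc2O)c(=O)c2cc(F)c(N3CCNC(C)C3)c(F)c21`) gives 24800 nM here, while compound 3 (`CCn1cc(C(=O)Nc2ccc(C)c([N+](=O)[O-])c2)c(=O)c2cc(F)c(N3CCNC(C)C3)c(F)c21`) gives 3700 nM as the lowest of the three numbers. Compound 4 (`CCn1cc(C(=O)Nc2ccc(OC)cc2)c(=O)c2cc(F)c(N3CCNC(C)C3)c(F)c21`) has 4-methoxyphenyl in place of 4-methyl-3-nitrophenyl on an amide-type nitrogen. Of the measured steps, a 1.6-fold lower number from compound 1 to compound 2 (0.20 log units; within the scatter) lies within the scatter and says little. Among the compounds with values here, because an 11-fold lower number from compound 1 to compound 3 (1.03 log units; beyond the scatter) is large and a 6.7-fold lower number from compound 2 to compound 3 (0.83 log units; beyond the scatter) modest, both with 4-methyl-3-nitrophenyl entering, a higher number is expected once that group leaves, though 4-methoxyphenyl itself has no measurement yet. The estimated step, a 4.9-fold higher number from compound 3 to compound 4 (0.69 log units; beyond the scatter) and so modest to large, runs towards weaker inhibition. Compound 4 is estimated at 18000 nM within an expected range of 7000 nM to 40000 nM for now.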

Compound 4, half-maximal inhibitory concentration: 9700 nM
Compound 4: middle estimate off by 1.9-fold (0.27 log units), on the high side, within the range that was stated.
By their numbers in this assay, from the lowest: compound 3; then compound 4; then compounds 2 and 1 (each within the scatter of the next).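

Replacing phenyl with 4-methoxyphenyl gives a 4.1-fold lower number from compound 1 to compound 4 (0.61 log units; beyond the scatter) in this assay and so moves the number beyond the scatter, which the hydroxy step to compound 2 did not do. The change from 2-hydroxyphenyl to 4-methoxyphenyl also reads beyond the scatter, with a 2.6-fold lower number from compound 2 to compound 4 (0.41 log units; beyond the scatter) as its step. Compound 3 still stays ahead, with a 2.6-fold higher number from compound 3 to compound 4 (0.42 log units; beyond the scatter) showing that 4-methoxyphenyl recovers only part of the drop seen with 4-methyl-3-nitrophenyl.

Open, on these data alone, are the separate contributions of the 4-methyl and 3-nitro groups and the reading of an amine or carboxylic acid on this ring. No supporting data bear on these differences.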